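A few compounds are considered here, and "the series" means these few. Any claim that something is new, unique, unknown or untested is made for them only; others in the source may bear on it.

Two compounds sharing one core have so far been examined in a physicochemical assay for solubility, read by HPLC, with a stated time of 4 h, at pH 7; on this read-out higher numbers stand for higher solubility and lower numbers for lower solubility. Compound 1 `Cc1ccc(NC(=O)Nc2ccc(OC[C@@]3(C)Cn4cc([N+](=O)[O-])nc4O3)cc2)cc1` gives < 1 ug/mL in this assay, a limit of the assay rather than a measured number. Compound 2 `C[C@]1(COc2ccc(NC(=S)Nc3ccc(OC(F)(F)F)cc3)cc2)Cn2cc([N+](=O)[O-])nc2O1` also returns only a limit: in this assay compound 2 gives < 1 ug/mL. On the numbers shown, compound 2 therefore stands at the floor of what this assay reports, and that floor is where every value so far sits, (the limit of < 1 ug/mL in this assay, at which 2 of the 2 values shown sit). Compound 3 `COc1ccc(NC(=S)Nc2ccc(OC[C@@]3(C)Cn4cc([N+](=O)[O-])nc4O3)cc2)cc1` is not yet measured. It differs from compound 2 in a single place: methyl in place of trifluoromethyl on an oxygen on an aromatic ring. Within the data shown here, no step between two measured compounds exists here, so any size for this change can only be an expectation. The step from compound 2 to compound 3 is expected to be an at least 1.5-fold higher number from compound 2 to compound 3 (0.17 log units; that floor lies within the scatter), an upward move that is modest and may still leave the reading at a limit. Compound 3 is estimated at 1.5 ug/mL in this assay, with a plausible range from 0.4 ug/mL to 6 ug/mL.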

Compound 3, solubility: 8.66 ug/mL
Estimate against measurement, compound 3: 5.8-fold (0.76 log units) below; measured number above the stated range.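

In this assay, trifluoromethoxy giving way to methoxy on the aromatic ring produces the first step that can be read among these compounds: an at least 8.6-fold higher number from compound 2 to compound 3 (0.93 log units; beyond the scatter). Compound 2 gives < 1 ug/mL, which is a limit of the assay and not a number, so this step has a lower bound but no known full size. The earlier compounds showed only the floor, whereas this pair shows that the shared core does not tie every member to it and that the group on this oxygen can move the reading clear of the floor, which still holds the other values: the limit of < 1 ug/mL in this assay, at which 2 of the 3 values shown sit.

What the compounds shown leave open is how far this position can be taken, for instance whether a longer chain such as ethyl on the same oxygen, or an amine in place of the whole methoxy group, would read like compound 3 or fall back to the floor. From the compounds shown here alone, it also remains open whether the same exchange would bring a similar step in a compound carrying the carbonyl of compound 1, and this single pair does not say why the reading moves.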